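The source may report more compounds than this note shows. Statements on the series, on what has been measured and on what is new or still open speak of the compounds shown alone.

In an ADME assay on MDBK cells (Bos taurus) for cytotoxicity (on this read-out higher numbers stand for lower toxicity in this test and lower numbers for higher toxicity in this test), three compounds that share one core and differ in a single group have been measured so far. Compound 1 `COc1ccc(Cn2ccc3nc(-c4ccccc4)nc-3c2)cc1` gives > 100000 nM, which is a limit of the assay and not a number. Compound 2 `Fc1ccccc1Cn1ccc2nc(-c3ccccc3)nc-2c1` gives > 100000 nM, again a limit. Compound 3 `CC(C)CCn1ccc2nc(-c3ccccc3)nc-2c1` gives > 100000 nM, also a limit. The whole series therefore stands at one point: the limit of > 100000 nM in this assay, at which 3 of the 3 values shown sit.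

Compound 4 `CCC(CC)Cn1ccc2nc(-c3ccccc3)nc-2c1` keeps the core of compound 3 and changes one group: pentan-3-yl in place of isobutyl on a saturated chain carbon bound to an aromatic nitrogen. In words, pentan-3-yl comes in place of isobutyl on a saturated chain carbon bound to an aromatic nitrogen.

Among the measured compounds shown here, three measured steps touch this same place: a step that the two limits leave unreadable from compound 1 to compound 2, a step that the two limits leave unreadable from compound 1 to compound 3 and a step that the two limits leave unreadable from compound 2 to compound 3. For the measured compounds named here, none of them has a readable size, and no compound in them has left the limit. Their swaps among 4-methoxyphenyl, 2-fluorophenyl and isobutyl give no sign of a change, so no step beyond the usual scatter is expected in this assay. The true size could still be hidden behind the limit.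

The expected step is a number no higher from compound 3 to compound 4 (the limit leaves the size open). Compound 4 is estimated at 100000 nM, with an expected range from 50000 nM to 200000 nM, and it will most likely be reported as a limit again.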

Compound 4, half-maximal cytotoxic concentration: > 100000 nM
Compound 4: a limit, no number (the forecaster's own chance of this, stated with the estimate: 85%); the middle value sits exactly at the limit.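

In this assay compound 4 gives > 100000 nM, which is a limit and not a number. Among the compounds shown here, compound 1, compound 2 and compound 3 also sit at a limit, so no step from any of them to compound 4 can be read. The series stays at one point: the limit of > 100000 nM in this assay, at which 4 of the 4 values shown sit.

From the compounds shown here alone, whether these four groups differ at all in toxicity remains open.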